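A Methoxy for a Nitro: Tolerance on Liver Cells

This account rests on a few compounds, and the source may have more. Where it says the series, first, only, none or still open, it means among the compounds named here.

Compound 1 `CCOC(=O)c1cn(-c2ccc([N+](=O)[O-])cc2)nc1CC(C)C` gives > 100000 nM in a toxicity assay on HepG2 2.2.15 cells (Homo sapiens) for cytotoxicity, read by CCK-8 assay, with a stated time of 8 days (a lower number here means that less compound is tolerated, a higher number that more compound is tolerated), and this value is a limit of the assay rather than a number (the limit of > 100000 nM in this assay, at which 1 of the 3 values shown sits).
Compound 2 `CCOC(=O)c1cn(-c2cccc([N+](=O)[O-])c2)nc1CC(C)C` gives 59300 nM in this assay.
Compound 3 `CCOC(=O)c1cn(-c2ccc(OC)cc2)nc1CC(C)C` gives 77100 nM in this assay.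

The three measured compounds share one core and differ only in the group carried on the aromatic ring attached to it. Compound 3 differs from compound 1 by methoxy in place of nitro on an aromatic carbon. The step between them is an at least 1.2-fold lower number from compound 1 to compound 3 (0.11 log units; that floor lies within the scatter); because the value of compound 1 is a limit (the limit of > 100000 nM in this assay, at which 1 of the 3 values shown sits), only a floor for this step is known, and that floor lies within the scatter. Compound 2 has the same atoms as compound 1 joined differently; the difference between the two cores is not broken down here. The values of compound 2 and compound 3 lie within the scatter of one another.

Compound 4 `CCOC(=O)c1cn(-c2cccc(OC)c2)nc1CC(C)C` has not yet been measured. It differs from compound 2 by methoxy in place of nitro on an aromatic carbon. Within the data shown here, this is the same kind of change as the one from compound 1 to compound 3, but not the same: there the group sits para to a large group, here meta to a large group.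

For compound 4 a step of a 1.0-fold higher number from compound 2 to compound 4 (0.01 log units; within the scatter) is expected, resting on the measured step of an at least 1.2-fold lower number from compound 1 to compound 3 (0.11 log units; that floor lies within the scatter) and on the value of compound 2 in this assay, 59300 nM. The estimate for compound 4 is 60000 nM, expected to fall between 25000 nM and 130000 nM.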

Compound 4, half-maximal cytotoxic concentration: 70500 nM
For compound 4 the middle estimate is 1.2-fold (0.07 log units) below the measured one; measured number inside the range.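

On the core of compound 2, with the group meta to a large group, methoxy in place of nitro gives a 1.2-fold higher number from compound 2 to compound 4 (0.08 log units; within the scatter), so on this core the change leaves no mark that can be told apart from the ordinary scatter of repeated measurements. Compound 1 gives > 100000 nM in this assay, which is a limit of the assay and not a number. The two steps therefore cannot be shown either to match or to differ, so the small step on one core does not prove that the change has the same size on the other: the same change on two cores in this assay, an at least 1.2-fold lower number (0.11 log units; that floor lies within the scatter) from compound 1 to compound 3 and a 1.2-fold higher number (0.08 log units; within the scatter) from compound 2 to compound 4; the limit leaves it open whether they differ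

The compounds shown leave open how other groups would fare on the same aromatic ring, such as an amine or a carboxylic acid in place of the nitro or methoxy. They also leave open whether the swap of nitro for methoxy would give a similar result if the chain on the shared core were replaced by a longer chain.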